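The source may report more compounds than this note shows. Statements on the series, on what has been measured and on what is new or still open speak of the compounds shown alone.

Compounds measured in an ADME assay on HepG2 2.2.15 cells (Homo sapiens) for cytotoxicity; on this read-out lower numbers stand for higher toxicity in this test and higher numbers for lower toxicity in this test:
compound 1 `CC(=O)OCCc1c(-c2ccccc2Cl)c2cc(Cl)ccc2[nH]c1=O`, 27000 nM
compound 2 `CCCCC(=O)OCCc1c(-c2ccccc2Cl)c2cc(Cl)ccc2[nH]c1=O`, 200000 nM
compound 3 `COCC(=O)OCCc1c(-c2ccccc2Cl)c2cc(Cl)ccc2[nH]c1=O`, 74000 nM

Compound 1 gives the lowest of the three numbers in this assay; compound 3 stands nearest, and compound 2 furthest. Compound 4 `CC(=O)NCC(=O)OCCc1c(-c2ccccc2Cl)c2cc(Cl)ccc2[nH]c1=O` differs from compound 1 in one place: acetamido in place of hydrogen on a saturated chain carbon bound to a carbonyl carbon. Two measured steps start at the same position of compound 1 and both raise the number: a 7.4-fold higher number from compound 1 to compound 2 (0.87 log units; beyond the scatter) and a 2.7-fold higher number from compound 1 to compound 3 (0.44 log units; beyond the scatter). Both are modest yet beyond the scatter, so a group entering at this carbon in place of hydrogen has so far moved the number upward each time. Compound 4 is therefore expected to show a modest rise as well, a 2.8-fold higher number from compound 1 to compound 4 (0.44 log units; beyond the scatter). Compound 4 is estimated at 75000 nM, in a range from 30000 nM to 200000 nM.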

Compound 4, half-maximal cytotoxic concentration: 110000 nM
Beside the measured number, compound 4's estimate is 1.5-fold (0.17 log units) below it; the range from low to high includes it.
By their numbers in this assay, from the lowest: compound 1; then compounds 3, 4 and 2 (each within the scatter of the next, the first and the last beyond it).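

In this assay, acetamido is the third group at this carbon to raise the number over hydrogen, with a 4.1-fold higher number from compound 1 to compound 4 (0.61 log units; beyond the scatter), so all three groups entering here move it the same way. The result cannot be separated from either of the other two groups, with a 1.5-fold higher number from compound 3 to compound 4 (0.17 log units; within the scatter) and a 1.8-fold lower number from compound 2 to compound 4 (0.26 log units; within the scatter), so acetamido ranks neither above nor below methoxy or propyl here. Nothing measured on these compounds explains the rise. As far as these compounds go, whether an amine or a carboxylic acid at this carbon would also raise the number remains open, as does the effect of a chain longer than propyl.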